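Piperidine amine variation on the shared core

This account rests on a few compounds, and the source may have more. Where it says the series, first, only, none or still open, it means among the compounds named here.

Series sharing the core of compound 1 `CN(CC1CCN(CCCc2c[nH]c3ccc(-n4cnnc4)cc23)CC1)C(=O)Nc1ccccc1`, which in an assay on CHO cells for displacement of a labelled ligand from 5-hydroxytryptamine receptor 1D (Homo sapiens) (on this read-out higher numbers stand for weaker inhibition and lower numbers for stronger inhibition), gives 5.9 nM. Compound 2 `CN(Cc1cccs1)C1CCN(CCCc2c[nH]c3ccc(-n4cnnc4)cc23)CC1` gives 4.3 nM in this assay, and compound 3 `c1ccc(CNC2CCN(CCCc3c[nH]c4ccc(-n5cnnc5)cc34)CC2)cc1` gives 4.6 nM. Compound 3 sits in the middle of the three numbers; its nearest neighbour is compound 2 and its furthest is compound 1, both within the scatter of it. Within the data shown here, the only step measured in a single place, a 1.1-fold higher number from compound 2 to compound 3 (0.03 log units; within the scatter), shows that exchanging the amine on the saturated ring carbon leaves this assay unchanged beyond the scatter.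

Compound 4 `CN(Cc1ccccc1)CC1CCN(CCCc2c[nH]c3ccc(-n4cnnc4)cc23)CC1` differs from compound 3 by (benzyl(methyl)amino)methyl in place of benzylamino on a saturated ring carbon. Bearing on this are the step from compound 2 to compound 3, which was within the scatter, and compound 1, whose value of 5.9 nM also lies within the scatter of compound 3. No step beyond the scatter is therefore expected in this assay. Compound 4 is expected at 5 nM, with a range of 2 nM to 12 nM. The expected step is a 1.1-fold higher number from compound 3 to compound 4 (0.04 log units; within the scatter).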

Compound 4, half-maximal inhibitory concentration: 0.9 nM
Beside the measured number, compound 4's estimate is 5.6-fold (0.74 log units) above it; measured number outside the range, below it.
By their numbers in this assay, from the lowest: compound 4; then compounds 2, 3 and 1 (each within the scatter of the next).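

In this assay the group on this saturated ring carbon turns out to matter: (benzyl(methyl)amino)methyl in place of benzylamino gives a 5.1-fold lower number from compound 3 to compound 4 (0.71 log units; beyond the scatter) and in place of methyl((thiophen-2-yl)methyl)amino gives a 4.8-fold lower number from compound 2 to compound 4 (0.68 log units; beyond the scatter) whereas the exchange between those two earlier amines stayed within the scatter. The group on the amine nitrogen matters too, since benzyl in place of phenylcarbamoyl gives a 6.6-fold lower number from compound 1 to compound 4 (0.82 log units; beyond the scatter) with the rest of the molecule unchanged. Nothing available here accounts for these steps.

The step from compound 3 brings in a methyl on the amine nitrogen and an added methylene together, so the secondary amine benzylaminomethyl would be needed to tell the two apart. From the compounds shown here alone, how a longer chain to the amine or a fluorine on the benzyl ring would read in this assay also stays open.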